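This account rests on a few compounds, and the source may have more. Where it says the series, first, only, none or still open, it means among the compounds named here.

Going by the values given here, compound 1 `COc1cc(/C=C/C(=O)c2cccc(NC(=O)c3ccc(Cl)c(Cl)c3)c2)ccc1O` is the first of the three measured compounds. In a functional assay on Vero cells (Chlorocebus sabaeus) for inhibition (a lower number here means a stronger inhibitor, a higher number a weaker inhibitor), compound 1 gives > 50 ug/mL, a limit of the assay and not a number. Compound 2 `COC(=O)C(=O)Nc1cccc(C(=O)/C=C/c2ccc(O)c(OC)c2)c1` is the second; in this assay compound 2 gives 3.55 ug/mL. Compound 3 `CCOC(=O)C(=O)Nc1cccc(C(=O)/C=C/c2ccc(O)c(OC)c2)c1` is the third. In this assay compound 3 gives > 50 ug/mL, again a limit and not a number.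

Compound 3 therefore stands at the limit, and only compound 2 provides a number, since (the limit of > 50 ug/mL in this assay, at which 2 of the 3 values shown sit). The unmeasured compound 4 `COc1cc(/C=C/C(=O)c2cccc(NC(C)=O)c2)ccc1O` differs from compound 3 in one place: methyl in place of ethoxycarbonyl on a carbonyl carbon. Among the compounds with values here, no measured step tests this exact exchange. The nearest is an at least 14-fold higher number from compound 2 to compound 3 (1.14 log units; beyond the scatter), a large step, and an at least 14-fold lower number from compound 1 to compound 2 (1.14 log units; beyond the scatter) is also large, while a step that the two limits leave unreadable from compound 1 to compound 3 cannot be read between two limits. Within the data shown here, both measured compounds that differ from compound 2 sit at the limit, so the change to a small acetamido group has no close precedent here.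

Compound 4 is expected to give about 20 ug/mL in this assay, with a range from 3 ug/mL to 60 ug/mL. The estimated step of an at least 2.5-fold lower number from compound 3 to compound 4 (0.39 log units; beyond the scatter) is expected to bring compound 4 back below the limit, though this remains uncertain.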

Compound 4, half-maximal inhibitory concentration: 14.5 ug/mL
Beside the measured number, compound 4's estimate is 1.4-fold (0.14 log units) above it; low and high end bracket the measured number.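

In this assay, compound 4 shows that this carbonyl carbon does not need an oxalyl ester to keep a measurable value: methyl in place of ethoxycarbonyl gives an at least 3.4-fold lower number from compound 3 to compound 4 (0.53 log units; beyond the scatter), and methyl in place of 3,4-dichlorophenyl gives an at least 3.4-fold lower number from compound 1 to compound 4 (0.53 log units; beyond the scatter). Methyl still does not match methoxycarbonyl, with a 4.1-fold higher number from compound 2 to compound 4 (0.61 log units; beyond the scatter), so compound 2 remains the strongest of the four, and the values do not run in one direction with group size, as methyl falls between methoxycarbonyl and ethoxycarbonyl. The steps that start from compound 1 and compound 3 rest on limits and not on numbers, so their true sizes stay unknown: the limit of > 50 ug/mL in this assay, at which 2 of the 4 values shown sit.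

What the compounds shown leave open is whether the sharp difference between methoxycarbonyl and ethoxycarbonyl belongs to the ester alone. A carboxylic acid, a primary amide or a longer alkyl chain on this carbonyl carbon could fall on either side of compound 2 or compound 4, and nothing here decides which.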